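Swapping a phenol hydroxy for fluorine in a bromoaryl enone

The compounds below may be only part of what the source reports. "The series", "measured", "known", "first", "only" and "open" are said of these compounds alone.

Measured so far:
compound 1, `COc1cc(/C=C(/Sc2ccc(Br)cc2)C(=O)c2ccc(Br)cc2)ccc1O`, 1000 nM
compound 2, `O=C(/C(=C\c1ccc(O)c([N+](=O)[O-])c1)Sc1ccc(Br)cc1)c1ccc(Br)cc1`, 1000 nM
compound 3, `O=C(/C(=C\c1ccc(F)c([N+](=O)[O-])c1)SCc1ccc(F)cc1)c1ccc(SCc2ccc(F)cc2)c([N+](=O)[O-])c1`, 25000 nM

In a functional assay on DU-145 cells (Homo sapiens) for inhibition, read by trypan blue exclusion, with a stated time of 96 h (a higher number here means a weaker inhibitor of growth, a lower number a stronger inhibitor of growth), compound 1 gives 1000 nM. It stands level with compound 2 and, together with it, at the lowest of the three numbers; compound 3 sits far higher, and that gap lies beyond the scatter. Within the data shown here, the only single step available, no change at the digits printed from compound 1 to compound 2 (within the scatter), shows no change, but it concerns a nitro in place of methoxy and does not touch the group that is altered here.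

Compound 4, `COc1cc(/C=C(/Sc2ccc(Br)cc2)C(=O)c2ccc(Br)cc2)ccc1F`, differs from compound 1 by fluoro in place of hydroxy on an aromatic carbon. Among the measured compounds shown here, no measured pair isolates this exchange. Compound 3 carries a fluoro at the same position of its left-hand ring yet differs in several other places, so its high value cannot be read as the effect of fluorine alone. The expectation is therefore a modest weakening, a 2.5-fold higher number from compound 1 to compound 4 (0.40 log units; beyond the scatter), with wide uncertainty. Compound 4 is estimated at 2500 nM, with a range from 800 nM to 8000 nM.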

Compound 4, concentration for 50% growth inhibition: 10000 nM
Compound 4: the middle estimate sits 4.0-fold (0.60 log units) below what was measured; the whole stated range lies below it.
By their numbers in this assay, from the lowest: compounds 1 and 2 (each within the scatter of the next); then compound 4; then compound 3.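

In this assay, fluoro in place of the hydroxy of the 4-hydroxy-3-methoxyphenyl group gives a 10-fold higher number from compound 1 to compound 4 (1.00 log units; beyond the scatter), so this single exchange, with the rest of the core unchanged, is enough to weaken growth inhibition. The same ring showed no such sensitivity when its methoxy was exchanged, where nitro in place of methoxy gave no change at the digits printed from compound 1 to compound 2 (within the scatter), so among these compounds the hydroxy is the group whose exchange makes a difference. No measurement here gives a reason for this loss.

The compounds shown leave open how an amine or a carboxylic acid would behave in place of the hydroxy, which would show whether other groups can stand in for it. From the compounds shown here alone, it also remains open whether fluoro would cost as much on the nitro-bearing ring of compound 2.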